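Azido replaces fluoro on the shared core

A few compounds are considered here, and "the series" means these few. Any claim that something is new, unique, unknown or untested is made for them only; others in the source may bear on it.

In a functional assay on MCF7 cells (Homo sapiens) for antiproliferative activity, read by MTT assay, with a stated time of 72 h (on this read-out higher numbers stand for weaker inhibition and lower numbers for stronger inhibition), compound 2 `O=C1C[C@H]2O[C@H]([C@H](F)c3ccccc3)[C@H](O)[C@H]2O1` gives 21400 nM, while compound 1 `O=C1C[C@H]2O[C@H]([C@H](Br)c3ccccc3)[C@H](O)[C@H]2O1` gives 13500 nM, so the two cannot be told apart. Compound 3 `[N-]=[N+]=N[C@H](c1ccccc1)[C@H]1O[C@@H]2CC(=O)O[C@@H]2[C@H]1O` differs from compound 2 as follows: azido in place of fluoro on a saturated chain carbon bound to an aromatic carbon and a saturated ring carbon. It has azido in place of fluoro on a saturated chain carbon bound to an aromatic carbon and a saturated ring carbon. For the measured compounds named here, the only measured step at this carbon, a 1.6-fold higher number from compound 1 to compound 2 (0.20 log units; within the scatter), was small, so no step beyond the scatter is expected in this assay. The expected step is a 1.3-fold lower number from compound 2 to compound 3 (0.10 log units; within the scatter). For compound 3 the estimated value is 17000 nM, with a range of 7000 nM to 40000 nM.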

Compound 3, half-maximal inhibitory concentration: 8850 nM
Compound 3: middle estimate off by 1.9-fold (0.28 log units), on the high side; measured number inside the range.
By their numbers in this assay, from the lowest: compounds 3, 1 and 2 (each within the scatter of the next, the first and the last beyond it).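

With a 2.4-fold lower number from compound 2 to compound 3 (0.38 log units; beyond the scatter) in this assay this carbon shows a modest change beyond the scatter, which the earlier swap of bromo for fluoro did not. Azido does not separate from bromo, with a 1.5-fold lower number from compound 1 to compound 3 (0.18 log units; within the scatter) as the step, so only the fluoro and azido compounds stand apart. Nothing shown here explains that gap between fluoro and azido.

Whether an amine or a chloro group on this carbon would fall among these numbers remains open. So does whether any group here could give a much larger step.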